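From Fluoro to Acetamido on an Aromatic Carbon

The source may hold more compounds than are shown below. What is called first, only, known or untested is meant among the compounds shown, and "the series" means these compounds.

In a functional assay on QGY-7703 cells (Homo sapiens) for cytotoxicity, read by MTT assay, with a stated time of 24 h (a higher number here means a weaker inhibitor, a lower number a stronger inhibitor), compound 1 `O=C1/C(=C/c2cccnc2)CN(S(=O)(=O)c2ccc([N+](=O)[O-])cc2)C/C1=C\c1ccccc1C(F)(F)F` gives 7660 nM and compound 2 `O=C1/C(=C/c2cccnc2)CN(S(=O)(=O)c2ccc(F)cc2)C/C1=C\c1ccccc1C(F)(F)F` gives 6030 nM as its result. Among the measured compounds shown here, these are the only two measurements so far, and they lie within the usual scatter of each other, so compound 2 cannot be told apart from compound 1.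

The next molecule is compound 3 `CC(=O)Nc1ccc(S(=O)(=O)N2C/C(=C\c3cccnc3)C(=O)/C(=C/c3ccccc3C(F)(F)F)C2)cc1`, which has acetamido in place of fluoro on an aromatic carbon, para to a large group: acetamido in place of fluoro on an aromatic carbon.

For the measured compounds named here, only one measured step bears on this change. That step, a 1.3-fold lower number from compound 1 to compound 2 (0.10 log units; within the scatter), also exchanges one group for another on an aromatic carbon, and it stayed within the scatter. This is thin evidence, since it rests on a single pair and acetamido itself has not yet been tested. No step beyond the scatter is therefore expected in this assay, in either direction.

The expected step is a 1.1-fold higher number from compound 2 to compound 3 (0.03 log units; within the scatter), which would be too small to separate the two compounds. Compound 3 is estimated at 6500 nM, with 2500 nM to 16000 nM as the expected range.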

Compound 3, half-maximal inhibitory concentration: 5380 nM
The estimate for compound 3 lay 1.2-fold (0.08 log units) above the measured number; the range from low to high includes it.
By their numbers in this assay, from the lowest: compounds 3, 2 and 1 (each within the scatter of the next).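

In this assay, acetamido in place of fluoro gives a 1.1-fold lower number from compound 2 to compound 3 (0.05 log units; within the scatter), and acetamido in place of nitro gives a 1.4-fold lower number from compound 1 to compound 3 (0.15 log units; within the scatter) on the same aromatic carbon. Among the compounds shown here, this is the first test of a group with a hydrogen-bond donor and a hydrogen-bond acceptor in place of fluoro, and with more heavy atoms as well, yet the number stays within the scatter, leaving compounds 1, 2 and 3 impossible to tell apart at this position. Nothing measured on these compounds offers an explanation for this flat result.

Still open, on these data alone, is whether a very different group at this place, such as a free amine, a carboxylic acid or a longer chain in place of the acetyl part of acetamido, would produce a step beyond the scatter. The three compounds also share everything outside this one position, which leaves unknown how changes elsewhere on the shared core would read, and whether this lack of separation would hold in other cells or at other exposure times.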